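Cyclohexyl diaryl ureas: swapping the bromophenyl for fluorophenyl

A few compounds are considered here, and "the series" means these few. Any claim that something is new, unique, unknown or untested is made for them only; others in the source may bear on it.

Compound 1, `O=C(Nc1ccc(Br)cc1)N[C@H]1CC[C@H](Oc2ccc(F)cc2)CC1`, in a functional assay on CRL2813 cells (Homo sapiens) for cytotoxicity, read by sulforhodamine B assay, with a stated time of 5 days (a lower number here means a stronger inhibitor, a higher number a weaker inhibitor), gives > 20000 nM.
Compound 2, `COC(=O)c1ccc(NC(=O)N[C@H]2CC[C@H](Oc3ccc(F)cc3)CC2)cc1`, in this assay gives 11600 nM.
Compound 3, `O=C(Nc1cccc(C(F)(F)F)c1)N[C@H]1CC[C@@H](Oc2ccc(F)cc2)CC1`, in this assay gives 2600 nM.

Compound 1 stands at the limit of this assay; its figure is a limit rather than a measured number, as the limit of > 20000 nM in this assay, at which 1 of the 3 values shown sits, makes plain. Compound 2 and compound 3 both give numbers, with compound 3 giving the lower of the two.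

The unmeasured compound 4, `O=C(Nc1ccccc1F)N[C@H]1CC[C@H](Oc2ccc(F)cc2)CC1`, differs from compound 1 in one place: 2-fluorophenyl in place of 4-bromophenyl on an amide-type nitrogen. Among the compounds with values here, the only measured step that bears on the aryl group on that nitrogen is an at least 1.7-fold lower number from compound 1 to compound 2 (0.23 log units; that floor lies within the scatter), and that step is a floor that lies within the scatter, so it gives no sign that the aryl group moves the number far. Compound 4 is thus expected to show a step of a number no higher from compound 1 to compound 4 (the limit leaves the size open), that is, no change beyond the scatter. Compound 4 is estimated at 20000 nM, within 7000 nM to 50000 nM, with a fair chance that only a limit is reported.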

Compound 4, half-maximal inhibitory concentration: 17500 nM
Compound 4: the middle estimate sits 1.1-fold (0.06 log units) above what was measured; the measured number falls inside the stated range.
By their numbers in this assay, from the lowest: compound 3; then compounds 2 and 4 (each within the scatter of the next). At a limit, above all of these: compound 1.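

In this assay, 2-fluorophenyl in place of 4-bromophenyl on the amide-type nitrogen gives compound 4 a measured number, 17500 nM. The change reads as an at least 1.1-fold lower number from compound 1 to compound 4 (0.05 log units; that floor lies within the scatter), so, like the earlier step to the methoxycarbonyl group, it gives no sign of a move beyond the scatter at this position. The true size of the step stays open because compound 1 carries only a limit: the limit of > 20000 nM in this assay, at which 1 of the 4 values shown sits.

This change replaces the bromine with fluorine and also alters the group's name from 4-bromophenyl to 2-fluorophenyl, and the compounds shown do not separate these two differences. Going by these compounds, a 2-bromophenyl group would separate them, and what an amine or a carboxylic acid on that aromatic ring would do remains open.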